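The compounds below may be only part of what the source reports. "The series", "measured", "known", "first", "only" and "open" are said of these compounds alone.

Among the compounds with values here, in a physicochemical assay for lipophilicity, read by LC-MS, in phosphate buffer, measured as octanol-water partition, with a stated time of 30 min, at pH 7.4, tested at 200 mM (on this read-out higher numbers stand for higher lipophilicity and lower numbers for lower lipophilicity), compound 2 `Cc1cccnc1Oc1ccc2nc(COc3cccc(C(=O)O)c3)n(C)c2c1` gives 0.9, and its only neighbour, compound 1 `Cc1cccc(Oc2ccc3nc(COc4cccc(C(=O)O)c4)n(C)c3c2)n1`, gives 0.8, a pair whose step a number 0.10 log units higher from compound 1 to compound 2 (within the scatter) lies within the scatter. Compound 3 `Cc1cc(F)cnc1Oc1ccc2nc(COc3cccc(C(=O)O)c3)n(C)c2c1` differs from compound 2 by fluoro in place of hydrogen on an aromatic carbon. Within the data shown here, no measured step shows a fluoro entering for a hydrogen; the single step seen moves only a methyl and is within the scatter, so it gives no guide here. A modest rise in this assay is expected for compound 3, about a number 0.20 log units higher from compound 2 to compound 3 (within the scatter), giving an estimated 1.1, between 0.8 and 1.5.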

Compound 3, distribution coefficient: 1.1
Compound 3: the middle estimate sits on the measured number at the digits printed, and the stated range covers the measured number.
By their numbers in this assay, from the lowest: compounds 1, 2 and 3 (each within the scatter of the next).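

Within the data shown here, with this fluoro on an aromatic carbon, two atoms from the ring nitrogen, this assay gives a first reading for a halogen at this position: a number 0.20 log units higher from compound 2 to compound 3 (within the scatter). Set against the group of compound 1, 5-fluoro-3-methylpyridin-2-yl gives a number 0.30 log units higher from compound 1 to compound 3 (within the scatter), so this change too stays inside the scatter. No independent evidence accounts for either step. Still open, from the compounds shown here alone, is whether a chloro or a methoxy group on the same carbon would give a step beyond the scatter. Also open, going by these compounds, is whether fluoro in place of hydrogen reads alike on the 6-methylpyridin-2-yl group.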